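The source may report more compounds than this note shows. Statements on the series, on what has been measured and on what is new or still open speak of the compounds shown alone.

Compound 1 `Oc1ccccc1-c1cc(-c2ccccc2F)cc(-c2ccccc2O)n1` — in a functional assay on T47D cells (Homo sapiens) for inhibition (on this read-out lower numbers stand for stronger inhibition and higher numbers for weaker inhibition), compound 1 gives > 50000 nM, which is a limit of the assay rather than a number.
Compound 2 `Oc1ccc(-c2cc(-c3ccccc3F)cc(-c3ccccc3O)n2)cc1` — in this assay compound 2 gives > 50000 nM, again a limit and not a number.
Compound 3 `Oc1ccc(-c2cc(-c3ccc(F)cc3)cc(-c3ccccc3O)n2)cc1` — in this assay compound 3 gives > 50000 nM, also a limit.

Compound 2 therefore stands exactly where the other two stand: every value shown sits at the limit of > 50000 nM in this assay, at which 3 of the 3 values shown sit, so no number places compound 2 above or below compound 1 or compound 3. The compound not yet measured is compound 4 `Oc1ccc(-c2cc(-c3ccccc3F)cc(-c3ccc(O)cc3)n2)cc1`, and the change that leads to it from compound 2 is 4-hydroxyphenyl in place of 2-hydroxyphenyl on an aromatic carbon. Among the measured compounds shown here, two measured steps bear on this kind of change, a step that the two limits leave unreadable from compound 1 to compound 2 and a step that the two limits leave unreadable from compound 2 to compound 3, and both join values that are limits, so neither reveals a size or a direction. Since all three measured compounds sit at the limit of > 50000 nM in this assay, at which 3 of the 3 values shown sit, the expectation for compound 4 is that it, too, stays at the limit, with no step beyond the scatter readable. The expected step from compound 2 to compound 4 is therefore a number no higher from compound 2 to compound 4 (the limit leaves the size open). The estimate for compound 4 is 50000 nM, with a range from 20000 nM to 150000 nM, and most likely the assay will again report only a limit.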

Compound 4, half-maximal inhibitory concentration: 15100 nM
Estimate against measurement, compound 4: 3.3-fold (0.52 log units) above; the whole stated range lies above it.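

In this assay, among the compounds shown here, this change gives the first readable step: an at least 3.3-fold lower number from compound 2 to compound 4 (0.51 log units; beyond the scatter). The two groups have the same atoms and the same counts under the computed comparison, so what differs at this position, next to the ring nitrogen, is only where the hydroxyl sits on the phenyl ring, and that alone takes compound 4 off the limit. The same kind of change at the other hydroxyphenyl site, from compound 1 to compound 2, cannot be read, and neither can the fluorophenyl change from compound 2 to compound 3, so the new step gives only a minimum size, and the series as a whole stays mostly out of reach of a number: the limit of > 50000 nM in this assay, at which 3 of the 4 values shown sit.

The compounds shown leave open whether the hydroxyl itself matters at this position, or whether a 4-methoxyphenyl, 4-aminophenyl or 4-carboxyphenyl group there would serve as well. They also leave open how the 4-fluorophenyl group of compound 3 would behave alongside the two 4-hydroxyphenyl groups of compound 4, and whether any further change could bring the value lower still.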